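Swapping one aromatic group: from compound 2 to compound 3

The source may hold more compounds than are shown below. What is called first, only, known or untested is meant among the compounds shown, and "the series" means these compounds.

In a functional assay on HCT-116 cells (Homo sapiens) for inhibition, read by sulforhodamine B assay, with a stated time of 48 h, tested at 50 uM (on this read-out higher numbers stand for more inhibition of growth at the one concentration tested and lower numbers for less inhibition of growth), compound 2 `COc1ccc([C@@H]2C/C(=N/OCc3cn(-c4cc(OC)c(OC)c(OC)c4)nn3)c3cc(CC=C(C)C)c(OC)cc3O2)cc1` stands lower at 29% while compound 1 `COc1ccc([C@@H]2C/C(=N/OCc3cn(-c4ccc(C#N)cc4)nn3)c3cc(CC=C(C)C)c(OC)cc3O2)cc1` reaches 50% on the same read-out. Compound 3 `COc1ccc([C@@H]2C/C(=N/OCc3cn(-c4cccnc4Cl)nn3)c3cc(CC=C(C)C)c(OC)cc3O2)cc1` swaps the group on the aromatic nitrogen, with 2-chloropyridin-3-yl in place of 3,4,5-trimethoxyphenyl on an aromatic nitrogen as the full difference. For the measured compounds named here, only one measured step bears on this, a number 21 percentage points lower from compound 1 to compound 2 (beyond the scatter) at that same place, and it arrived with the 3,4,5-trimethoxyphenyl group that now leaves. Part of that loss may return, so the expected change is a number 11 percentage points higher from compound 2 to compound 3 (beyond the scatter) in the upward direction. Compound 3 is estimated at 40% with a likely range from 22% to 58% in this measurement.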

Compound 3, percent growth inhibition at one concentration: 47%
Estimate against measurement, compound 3: 7 percentage points below; measured number inside the range.
By their numbers in this assay, from the lowest: compound 2; then compounds 3 and 1 (each within the scatter of the next).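

In this assay the loss seen with 3,4,5-trimethoxyphenyl does not hold for every other ring at this position, as the change to 2-chloropyridin-3-yl gives a number 18 percentage points higher from compound 2 to compound 3 (beyond the scatter). Two different rings can also serve about equally here, with a number 3 percentage points lower from compound 1 to compound 3 (within the scatter) on replacing 4-cyanophenyl. No available measurement gives a reason for these differences. Going by these compounds, what remains open is whether an aromatic ring is needed on this nitrogen at all. A simple alkyl chain or a phenyl ring carrying an amine would test that.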